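Bromo for chloro on a benzofuran amidoxime pair

The source may hold more compounds than are shown below. What is called first, only, known or untested is meant among the compounds shown, and "the series" means these compounds.

Measured so far in an assay on tissue (HeLa cells) for inhibition of Indoleamine 2,3-dioxygenase 1 (Homo sapiens), read by spectrophotometry; on this read-out lower numbers stand for stronger inhibition and higher numbers for weaker inhibition:
compound 1, `OCc1cc2cc(/C(=N\O)Nc3cccc(Cl)c3)ccc2o1`, gives 5900 nM;
compound 2, `OCc1cc2cc(/C(=N\O)Nc3cccc(Br)c3)ccc2o1`, gives 1200 nM;
compound 3, `O/N=C(/Nc1cccc(Cl)c1)c1ccc2oc(COCC3CC3)cc2c1`, gives 17600 nM.

Compound 2 differs from compound 1 by bromo in place of chloro on an aromatic carbon. That change gave a 4.9-fold lower number from compound 1 to compound 2 (0.69 log units; beyond the scatter). Compound 3 differs from compound 1 by cyclopropylmethyl in place of hydrogen on an oxygen on a saturated carbon, and that change gave a 3.0-fold higher number from compound 1 to compound 3 (0.47 log units; beyond the scatter); compound 3 thus holds the highest number of the three.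

Compound 4, `O/N=C(/Nc1cccc(Br)c1)c1ccc2oc(COCC3CC3)cc2c1`, is not yet measured. It differs from compound 3 by bromo in place of chloro on an aromatic carbon. Going by the values given here, this is the same change as the one from compound 1 to compound 2, made at the same place on a core that carries the cyclopropylmethyl group. If it carries over, compound 4 is expected to show a step of about a 4.9-fold lower number from compound 3 to compound 4 (0.69 log units; beyond the scatter) in this assay , resting on the earlier 4.9-fold lower number from compound 1 to compound 2 (0.69 log units; beyond the scatter). Compound 4 is therefore estimated at 3600 nM, probably between 1700 nM and 7600 nM.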

Compound 4, half-maximal inhibitory concentration: 3200 nM
Beside the measured number, compound 4's estimate is 1.1-fold (0.05 log units) above it; the range from low to high includes it.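

In this assay, bromo in place of chloro gave a 5.5-fold lower number from compound 3 to compound 4 (0.74 log units; beyond the scatter), which matches the same change on the core of compound 1: the same change on two cores in this assay, a 4.9-fold lower number (0.69 log units; beyond the scatter) from compound 1 to compound 2 and a 5.5-fold lower number (0.74 log units; beyond the scatter) from compound 3 to compound 4, 1.1-fold (0.05 log units) apart, within the scatter of two such steps. Cyclopropylmethyl in place of hydrogen on the oxygen gave a 2.7-fold higher number from compound 2 to compound 4 (0.43 log units; beyond the scatter), and this also matches its earlier step: the same change on two cores in this assay, a 3.0-fold higher number (0.47 log units; beyond the scatter) from compound 1 to compound 3 and a 2.7-fold higher number (0.43 log units; beyond the scatter) from compound 2 to compound 4, 1.1-fold (0.05 log units) apart, within the scatter of two such steps. Across these four compounds, each change therefore had much the same effect whichever form the other place took, but this rests on only two cores and does not show why either change has its effect or that it would hold on any other core.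

Iodo or a nitrile at the same place on the aromatic ring remains open. So does whether an amine or a longer chain in place of cyclopropylmethyl would follow the same pattern.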